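A few compounds are considered here, and "the series" means these few. Any claim that something is new, unique, unknown or untested is made for them only; others in the source may bear on it.

Measured so far:
compound 1 `O=C(Nc1cc(Cl)nc(Cl)c1)Nc1cc2ccccn2n1`: 10200 nM
compound 2 `O=C(Nc1cc(Cl)nc(Cl)c1)Nc1cc2ccc(-c3ccccc3)cn2n1`: 8050 nM

In an ADME assay on NCM460 cells (Homo sapiens) for cytotoxicity, read by MTT assay, with a stated time of 72 h, in the presence of a further agent that is not named here (a higher number here means that more compound is needed for the effect, a lower number that less compound is needed), compound 2 has the lower of the two numbers, but the step of a 1.3-fold lower number from compound 1 to compound 2 (0.10 log units; within the scatter) lies within the scatter, so the two compounds cannot be set apart. Compound 3 `COc1ccc(-c2ccc3cc(NC(=O)Nc4cc(Cl)nc(Cl)c4)nn3c2)cc1` differs from compound 2 by methoxy in place of hydrogen on an aromatic carbon. For the measured compounds named here, the only step that bears on this is a 1.3-fold lower number from compound 1 to compound 2 (0.10 log units; within the scatter), which was within the scatter. The expected step is therefore a 1.2-fold lower number from compound 2 to compound 3 (0.06 log units; within the scatter), with no change beyond the scatter. For compound 3 the estimated value in this assay is 7000 nM, in a range from 3500 nM to 14000 nM.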

Compound 3, half-maximal effective concentration: 8350 nM
Estimate against measurement, compound 3: 1.2-fold (0.08 log units) below; low and high end bracket the measured number.
By their numbers in this assay, from the lowest: compounds 2, 3 and 1 (each within the scatter of the next).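

In this assay, methoxy on an aromatic carbon of the phenyl ring, para to a large group, gives a 1.0-fold higher number from compound 2 to compound 3 (0.02 log units; within the scatter) and so does not set compound 3 apart from compound 2. Taken as one change, 4-methoxyphenyl in place of hydrogen gives a 1.2-fold lower number from compound 1 to compound 3 (0.09 log units; within the scatter) and also stays within the scatter. No evidence accompanying these numbers speaks to a cause. The compounds shown leave open whether an amine or a carboxylic acid at this place on the phenyl ring would move the number beyond the scatter.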